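Side-chain variation on the shared core: cytotoxicity notes

A few compounds are considered here, and "the series" means these few. Any claim that something is new, unique, unknown or untested is made for them only; others in the source may bear on it.

Measured so far:
Compound 1 `CCCCC(O)CC(=O)O[C@H](CC=C(C)C)C1=CC(=O)c2c(O)ccc(O)c2C1=O`: 45300 nM
Compound 2 `CCC(C)(O)CC(=O)O[C@H](CC=C(C)C)C1=CC(=O)c2c(O)ccc(O)c2C1=O`: 16000 nM
Compound 3 `CC(C)=CC[C@@H](OC(=O)CC(C)(O)c1ccccc1)C1=CC(=O)c2c(O)ccc(O)c2C1=O`: not yet measured

Both measured compounds were run in a functional assay on DU-145 cells (Homo sapiens) for cytotoxicity, read by MTT assay; on this read-out higher numbers stand for weaker inhibition and lower numbers for stronger inhibition. Compound 2 holds the lower of the two numbers, and the gap is beyond the scatter: a 2.8-fold lower number from compound 1 to compound 2 (0.45 log units; beyond the scatter). That single step swaps one saturated group for another on a saturated chain carbon bound to a carbonyl carbon, with the hydroxyl retained in each case.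

Compound 3 keeps the hydroxyl and the methyl of compound 2 and differs only as follows: phenyl in place of ethyl on a saturated chain carbon bound to an oxygen on a saturated carbon and two saturated chain carbons. Among the measured compounds shown here, no measured step involves an aromatic ring entering at this place, so the only guidance is that changes in this part of the molecule have so far moved the number by a modest amount, as a 2.8-fold lower number from compound 1 to compound 2 (0.45 log units; beyond the scatter) shows. A step of comparable modest size is expected for compound 3, provisionally taken as a further lowering, with a change within the scatter or in the opposite direction not excluded: a 1.8-fold lower number from compound 2 to compound 3 (0.25 log units; within the scatter) is the estimated step. Compound 3 is therefore estimated at 9000 nM in this assay, with a range of 3000 nM to 30000 nM.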

Compound 3, half-maximal inhibitory concentration: > 100000 nM
Compound 3: no number, only a limit (the forecaster's own chance of this, stated with the estimate: 5%); middle value at least 11-fold (1.04 log units) away from the limit.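

In this assay, compound 3 has no number, only a limit: the limit of > 100000 nM in this assay, at which 1 of the 3 values shown sits.

Phenyl in place of ethyl at this chain carbon gives an at least 6.2-fold higher number from compound 2 to compound 3 (0.79 log units; beyond the scatter), and 1-hydroxy-1-phenylethyl in place of 1-hydroxypentyl gives an at least 2.2-fold higher number from compound 1 to compound 3 (0.34 log units; beyond the scatter), so the phenyl compound stands on the weak side of both saturated compounds, beyond the scatter in each case. Among the compounds shown here, the earlier compounds showed only that exchanging one saturated group for another at this place shifts a measurable number by a modest step; this result shows that the place is also sensitive in the weakening direction, and that with phenyl on this carbon the reading no longer yields a number at all.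

The compounds shown cannot tell whether the aromatic ring itself or simply the larger group is what matters, and a cyclohexyl group on the same carbon would separate the two. From the compounds shown here alone, how a phenyl ring carrying an amine or a carboxylic acid would read here, and how far above the limit compound 3 truly lies, also remain open.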